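The source may report more compounds than this note shows. Statements on the series, on what has been measured and on what is new or still open speak of the compounds shown alone.

Compound 1 `C#CCn1cc(C(=O)NC(CC(=O)Nc2ccccc2)c2ccccc2)c(=O)c2cc(F)c(Cl)nc21`. In a functional assay on KB cells (Homo sapiens) for cytotoxicity, read by MTT assay, with a stated time of 72 h (on this read-out higher numbers stand for weaker inhibition and lower numbers for stronger inhibition), compound 1 gives > 10000 nM, which is a limit of the assay and not a number.
Compound 2 `C#CCn1cc(C(=O)NC(CC(=O)Nc2ccccn2)c2ccccc2)c(=O)c2ccc(Cl)nc21`. In this assay compound 2 gives 5200 nM.
Compound 3 `C#CCn1cc(C(=O)NC(CC(=O)Nc2ccccc2)c2ccccc2)c(=O)c2ccc(Cl)nc21`. In this assay compound 3 gives > 10000 nM, again a limit of the assay.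
Compound 4 `C#CCn1cc(C(=O)NC(CC(=O)Nc2ccccc2)c2ccccc2)c(=O)c2cccnc21`, not yet measured.

Compound 3 stands only as a limit in this assay; the same limit, (the limit of > 10000 nM in this assay, at which 2 of the 3 values shown sit), holds two of the three values shown, so the position of compound 3 relative to compound 1 cannot be read. The change from compound 3 to compound 4 is hydrogen in place of chloro on an aromatic carbon.

Two measured steps end at compound 3. The step that the two limits leave unreadable from compound 1 to compound 3 is the closest analogue, a halogen on an aromatic carbon of the shared core replaced by hydrogen, but both ends sit at the limit and the size is not readable. The step of an at least 1.9-fold higher number from compound 2 to compound 3 (0.28 log units; that floor lies within the scatter) concerns the amide-type nitrogen, not the core, and its floor lies within the scatter. Going by the values given here, no measured step therefore gives the size of removing a halogen from the core.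

The expectation is that compound 4 stays at the limit, so the estimated step that the limit leaves unreadable from compound 3 to compound 4 means no readable change. Compound 4 is expected to give 15000 nM, in the range 5000 nM to 50000 nM.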

Compound 4, half-maximal inhibitory concentration: > 10000 nM
Compound 4: only a limit was reported; the forecaster's own chance of this, stated with the estimate: 75%; the middle value is on the limit's open side.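

In this assay compound 4 gives > 10000 nM as a limit of the assay, not a number. Going by these compounds alone, with compound 3 also at a limit, no step between compound 3 and compound 4 can be read. Whether removing a halogen from the shared core changes the read-out at all stays open across compound 1, compound 3 and compound 4: the limit of > 10000 nM in this assay, at which 3 of the 4 values shown sit.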